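Tetrazole aryl swap: chloro to carboxylic acid

A few compounds are considered here, and "the series" means these few. Any claim that something is new, unique, unknown or untested is made for them only; others in the source may bear on it.

Two compounds of the series carry numbers. In an assay on microsomes from brain for inhibition of Fatty-acid amide hydrolase 1 (Rattus norvegicus), read by fluorescence and HPLC, with a stated time of 60 min (a higher number here means a weaker inhibitor, a lower number a stronger inhibitor), compound 1 `CCCCCCCCc1ccc(OCC(=O)Cn2nnc(SC)n2)cc1` gives 31 nM, while compound 2 `CCCCCCCCc1ccc(OCC(=O)Cn2nnnc2-c2cccc(Cl)c2)cc1` gives 360 nM, the higher of the two and beyond the scatter from compound 1. Compound 3 `CCCCCCCCc1ccc(OCC(=O)Cn2nnnc2-c2ccc(C(=O)O)cc2)cc1` differs from compound 2 in one place: 4-carboxyphenyl in place of 3-chlorophenyl on an aromatic carbon. The entering group brings one hydrogen-bond donor and one hydrogen-bond acceptor where the leaving group had none. Going by the values given here, no measured pair changes this position, so the expected step toward a weaker inhibitor, a 2.2-fold higher number from compound 2 to compound 3 (0.35 log units; beyond the scatter) in this assay, is tentative. For compound 3 the estimate in this assay is 800 nM, between 200 nM and 3000 nM.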

Compound 3, half-maximal inhibitory concentration: 3400 nM
Compound 3: the middle estimate sits 4.3-fold (0.63 log units) below what was measured; measured number outside the range, above it.
By their numbers in this assay, from the lowest: compound 1; then compound 2; then compound 3.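

Going by these compounds alone, putting 4-carboxyphenyl in place of 3-chlorophenyl on this aromatic carbon of the five-membered ring gives, in this assay, a 9.4-fold higher number from compound 2 to compound 3 (0.98 log units; beyond the scatter) as the first measured step at this position. The position therefore responds to the aryl group it carries. The step changes both the substituent and where it sits on the phenyl ring, so this pair cannot separate the two, and no measurement at hand explains the step.

Still open, going by these compounds, is how unsubstituted phenyl would compare with both compounds. Also open, on these data alone, is whether a methyl ester or a primary amide would behave like the carboxylic acid.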